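A few compounds are considered here, and "the series" means these few. Any claim that something is new, unique, unknown or untested is made for them only; others in the source may bear on it.

In a functional assay (aorta) with Rattus norvegicus as the target (a lower number here means that less compound is needed, a higher number that more compound is needed for the effect), compound 1 `COc1ccc(-c2nc(/N=C(\N)NC(C)C)sc2-c2ccc(OC)cc2)cc1` gives 9.1 uM, compound 2 `COc1ccc(-c2nc(/N=C(\N)N(C)C)sc2-c2ccc(OC)cc2)cc1` gives 4.8 uM and compound 3 `C/N=C(/NC)Nc1nc(-c2ccc(OC)cc2)c(-c2ccc(OC)cc2)s1` gives 2.4 uM. Compound 3 cannot be separated from compound 2, since a 2.0-fold lower number from compound 2 to compound 3 (0.30 log units; within the scatter) lies within the scatter, whereas a 3.8-fold lower number from compound 1 to compound 3 (0.58 log units; beyond the scatter) lies beyond it. a 1.9-fold lower number from compound 1 to compound 2 (0.28 log units; within the scatter) also stays within the scatter.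

The next change leads to compound 4 `COc1ccc(-c2nc(/N=C(\N)[N+]3(C)CCCCC3)sc2-c2ccc(OC)cc2)cc1`: a group of 10 heavy atoms (7 carbon, 3 nitrogen; one six-membered non-aromatic ring with 1 hetero atom) in place of a group of 6 heavy atoms (3 carbon, 3 nitrogen; no ring), on an aromatic carbon. Going by the values given here, the entering group has one six-membered non-aromatic ring with 1 hetero atom and net charge +1, and no measured compound carries either feature. The measured steps therefore bear on this change only in part. The closest guide is a 3.8-fold lower number from compound 1 to compound 3 (0.58 log units; beyond the scatter), read in reverse, as compound 1 carries the group of 7 heavy atoms and has the higher number. On that slim basis, a modest rise in the number is expected in this assay, with wide uncertainty. The expected size of this change is a 2.9-fold higher number from compound 3 to compound 4 (0.46 log units; beyond the scatter). For compound 4 the estimated value is 7 uM, with an expected range of 2 uM to 25 uM.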

Compound 4, concentration for half-maximal effect: 21 uM
For compound 4 the middle estimate is 3.0-fold (0.48 log units) below the measured one, and the stated range covers the measured number.
By their numbers in this assay, from the lowest: compounds 3, 2 and 1 (each within the scatter of the next, the first and the last beyond it); then compound 4.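

In this assay, the group with one six-membered non-aromatic ring with 1 hetero atom and net charge +1 gives a higher number in every comparison: an 8.8-fold higher number from compound 3 to compound 4 (0.94 log units; beyond the scatter), a 4.4-fold higher number from compound 2 to compound 4 (0.64 log units; beyond the scatter) and a 2.3-fold higher number from compound 1 to compound 4 (0.36 log units; beyond the scatter), each beyond the scatter. Among the three compounds without a ring or net charge, the largest step at this position is a 3.8-fold lower number from compound 1 to compound 3 (0.58 log units; beyond the scatter), so the step to compound 4 from compound 3 is the largest shown for this series. Nothing available here accounts for the rise.

The ring and the net charge enter together in compound 4, so their separate contributions remain unresolved. A trimethylammonium group or a diethylamino group on the carbon with a double bond to nitrogen would help to separate them.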